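Fluoro on the pyridine ring across two thiourea cores

The compounds below may be only part of what the source reports. "The series", "measured", "known", "first", "only" and "open" are said of these compounds alone.

Compound 1 `N/C(=N\NC(=S)N1CCCCCC1)c1ccccn1` and compound 2 `N/C(=N\NC(=S)N1CCOCC1)c1ccccn1` carry different cores; the difference between the two cores is not broken down here. In a functional assay on HeLa cells (Homo sapiens) for cytotoxicity, read by MTT assay, with a stated time of 72 h, tested at 3 uM (on this read-out higher numbers stand for more inhibition of growth at the one concentration tested and lower numbers for less inhibition of growth), compound 1 gives 36.6% and compound 2 gives 40%, two numbers within the scatter of each other. Compound 3 `N/C(=N\NC(=S)N1CCOCC1)c1ccc(F)cn1` differs from compound 2 by fluoro in place of hydrogen on an aromatic carbon, and in this assay compound 3 gives 59.7%, a step of a number 19.7 percentage points higher from compound 2 to compound 3 (beyond the scatter). Compound 4 `N/C(=N\NC(=S)N1CCCCCC1)c1ccc(F)cn1` differs from compound 1 by fluoro in place of hydrogen on an aromatic carbon, the same change made on the other core. Because compound 1 gives 36.6% and compound 2 gives 40% in this assay, a step like a number 19.7 percentage points higher from compound 2 to compound 3 (beyond the scatter) is expected again, so compound 4 is expected to show a number 18.4 percentage points higher from compound 1 to compound 4 (beyond the scatter), resting on one pair only. The estimate for compound 4 in this assay is 55%, within 40% to 68%.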

Compound 4, percent growth inhibition at one concentration: 65.1%
Compound 4: middle estimate off by 10.1 percentage points, on the low side; low and high end bracket the measured number.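

In this assay, fluoro in place of hydrogen on an aromatic carbon of the core of compound 1 gives a number 28.5 percentage points higher from compound 1 to compound 4 (beyond the scatter). Set beside the earlier pair, the change carries from one core to the other in direction and, within the scatter, in size: the same change on two cores in this assay, a number 19.7 percentage points higher (beyond the scatter) from compound 2 to compound 3 and a number 28.5 percentage points higher (beyond the scatter) from compound 1 to compound 4, 8.8 percentage points apart, within the scatter of two such steps This rests on two pairs, one ring place, one cell type and one concentration, so it does not show that the step would hold on other cores or in other read-outs.

Going by these compounds, it remains open whether a chloro or a methoxy group in the same place gives a step of this kind. The same question stands for an amine or a carboxylic acid there.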